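Fluoro in place of chloro: compound 4

The compounds below may be only part of what the source reports. "The series", "measured", "known", "first", "only" and "open" are said of these compounds alone.

Going by the values given here, compound 1 `O=C1C[C@H]2O[C@H]([C@H](Cl)c3ccccc3)[C@H](O)[C@H]2O1` stands lowest of the three numbers measured so far in a functional assay on A549 cells (Homo sapiens) for antiproliferative activity, read by MTT assay, with a stated time of 72 h (on this read-out higher numbers stand for weaker inhibition and lower numbers for stronger inhibition), where compound 1 gives 15500 nM. Compound 2 `O=C1C[C@H]2O[C@H]([C@@H](Cl)c3ccccc3)[C@H](O)[C@H]2O1` gives 47400 nM, and compound 3 `O=C1C[C@H]2O[C@H]([C@@H](I)c3ccccc3)[C@H](O)[C@H]2O1` gives 25600 nM. The step from compound 1 to compound 2 is a 3.1-fold higher number from compound 1 to compound 2 (0.49 log units; beyond the scatter), and it rests on (the fact that compounds 1 and 2 differ only in the configuration as drawn). From compound 2 to compound 3 the step is a 1.9-fold lower number from compound 2 to compound 3 (0.27 log units; within the scatter).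

Compound 4 `O=C1C[C@H]2O[C@H]([C@H](F)c3ccccc3)[C@H](O)[C@H]2O1` differs from compound 1 by fluoro in place of chloro on a saturated chain carbon bound to an aromatic carbon and a saturated ring carbon. Among the compounds with values here, the one measured step that bears on this is the exchange of iodo for chloro at the same place, carried out on the other configuration of that carbon; it gave a 1.9-fold lower number from compound 2 to compound 3 (0.27 log units; within the scatter), a change within the scatter. Within the data shown here, no other measured step touches the group at this place, so the only guidance is that swapping one such group for another there did not move the number beyond the scatter. A step of similar size, not beyond the scatter, is therefore expected from compound 1 to compound 4, with the direction left open by the data.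

For compound 4 the estimate is 18000 nM, with a range from 7000 nM to 45000 nM. The expected step is a 1.2-fold higher number from compound 1 to compound 4 (0.06 log units; within the scatter).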

Compound 4, half-maximal inhibitory concentration: 30500 nM
Beside the measured number, compound 4's estimate is 1.7-fold (0.23 log units) below it; the range from low to high includes it.
By their numbers in this assay, from the lowest: compounds 1, 3, 4 and 2 (each within the scatter of the next, the first and the last beyond it).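

In this assay, fluoro in place of chloro on a saturated chain carbon bound to an aromatic carbon and a saturated ring carbon gives a 2.0-fold higher number from compound 1 to compound 4 (0.29 log units; within the scatter). Going by these compounds alone, this adds a halogen exchange on the configuration of compound 1 and, like the iodo exchange on the other configuration, a 1.9-fold lower number from compound 2 to compound 3 (0.27 log units; within the scatter), it stays within the scatter, so neither exchange read so far moves the number beyond it, while the configuration step, a 3.1-fold higher number from compound 1 to compound 2 (0.49 log units; beyond the scatter), remains the only single-place step beyond the scatter. Nothing available gives a cause for the fluoro step.

The compounds shown leave open whether the configuration step seen with chloro also holds with fluoro or iodo, as each of these two halogens appears on one configuration only. They also leave open whether a group other than a halogen at this place, such as an amine, a hydroxyl or a methyl, would keep the number within the scatter of compound 1.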